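This account rests on a few compounds, and the source may have more. Where it says the series, first, only, none or still open, it means among the compounds named here.

Of the compounds shown here, three built on one shared core have been measured in an assay on HEK293 cells for displacement of a labelled ligand from Melanocortin receptor 4 (Homo sapiens); on this read-out higher numbers stand for weaker inhibition and lower numbers for stronger inhibition. Compound 1 `CC(C)C[C@H](N)c1cc(C(F)(F)F)ccc1N1CCN(C(=O)[C@H](C)Cc2ccc(Cl)cc2)CC1` gives 31 nM. Compound 2 `CC(C)C[C@H](N)c1cc(C(F)(F)F)ccc1N1CCN(C(=O)CCNC2CCCCC2)CC1` carries a 2-(cyclohexylamino)ethyl group on the carbonyl carbon in place of the 1-(4-chlorobenzyl)ethyl group of compound 1. In this assay compound 2 gives 4800 nM; the step of a 150-fold higher number from compound 1 to compound 2 (2.19 log units; beyond the scatter) is the one large movement in this set. Compound 3 `CC(C)C[C@H](N)c1cc(C(F)(F)F)ccc1N1CCN(C(=O)C(C)Cc2ccc(Cl)cc2O)CC1` gives 36 nM; the step of a 1.2-fold higher number from compound 1 to compound 3 (0.06 log units; within the scatter) adds a hydroxyl to the benzyl ring without moving beyond the scatter, while the step of a 130-fold lower number from compound 2 to compound 3 (2.12 log units; beyond the scatter) mirrors the first large movement. Compound 3 thus stands second highest of the three numbers, close to compound 1 and far from compound 2.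

Compound 4 `COc1ccc(CC(C)C(=O)N2CCN(c3ccc(C(F)(F)F)cc3[C@@H](N)CC(C)C)CC2)cc1` has not yet been measured. It differs from compound 3 by 4-methoxyphenyl in place of 4-chloro-2-hydroxyphenyl on a saturated chain carbon, two bonds along the chain from a carbonyl carbon. Among the measured compounds shown here, no measured step exchanges a chlorine for a methoxy group on this ring, so the steps that bear on it are indirect: the presence of the aromatic ring made the large difference seen in the step of a 130-fold lower number from compound 2 to compound 3 (2.12 log units; beyond the scatter), whereas the hydroxyl on that ring barely registered in the step of a 1.2-fold higher number from compound 1 to compound 3 (0.06 log units; within the scatter). Since compound 4 keeps a six-membered aromatic ring of carbon only with one hydrogen-bond acceptor, only a small step is expected in this assay, if anything toward a slightly higher number. Compound 4 is expected to give 60 nM, within 20 nM to 200 nM, which would mean an estimated step of a 1.7-fold higher number from compound 3 to compound 4 (0.22 log units; within the scatter).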

Compound 4, inhibition constant: 120 nM
Compound 4: middle estimate off by 2.0-fold (0.30 log units), on the low side; measured number inside the range.
By their numbers in this assay, from the lowest: compounds 1 and 3 (each within the scatter of the next); then compound 4; then compound 2.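

In this assay, what sits at the 4-position of this ring does matter. The 4-methoxybenzyl group gives a 3.9-fold higher number from compound 1 to compound 4 (0.59 log units; beyond the scatter) when it replaces 4-chlorobenzyl and a 3.3-fold higher number from compound 3 to compound 4 (0.52 log units; beyond the scatter) when it replaces 4-chloro-2-hydroxybenzyl, both modest steps beyond the scatter, whereas the earlier hydroxyl change on the ring gave only a 1.2-fold higher number from compound 1 to compound 3 (0.06 log units; within the scatter) and stayed within it. The position is therefore sensitive to a swap on the ring, yet that swap costs far less than losing the benzyl group altogether, since the comparison with the cyclohexylamino compound still shows a 40-fold lower number from compound 2 to compound 4 (1.60 log units; beyond the scatter) in favour of the methoxy ring. No available evidence explains why the methoxy ring behaves differently from the chloro ring.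

From the compounds shown here alone, only chlorine and methoxy have been compared at this ring position, so it remains open whether a 4-methylbenzyl or 4-fluorobenzyl group would match the chloro compounds or fall nearer the methoxy one. It is also unknown whether a hydroxyl added to the 4-methoxybenzyl ring would be as silent as it was on the 4-chlorobenzyl ring.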